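The source may report more compounds than this note shows. Statements on the series, on what has been measured and on what is new or still open speak of the compounds shown alone.

Measured so far:
compound 1, `O=C(NCc1ccc(C(F)(F)F)nc1N1CCCCC1)Nc1cccc2[nH]c(=O)ccc12` — 0.75 nM
compound 2, `CC(C)COc1nc(C(F)(F)F)ccc1CNC(=O)Nc1cccc2[nH]c(=O)ccc12` — 2.6 nM

For the measured compounds named here, in an assay on HEK cells for antagonist activity at transient receptor potential cation channel subfamily V member 1 (Homo sapiens), read by FLIPR (a higher number here means a weaker inhibitor, a lower number a stronger inhibitor), compound 2 stands highest of the two numbers; its only neighbour is compound 1, and the single measured step, a 3.5-fold higher number from compound 1 to compound 2 (0.54 log units; beyond the scatter), was modest though beyond the scatter. Compound 3, `O=C(NCc1ccc(C(F)(F)F)nc1-c1ccc(F)cc1)Nc1cccc2[nH]c(=O)ccc12`, changes the same position again: 4-fluorophenyl in place of isobutoxy on an aromatic carbon. Going by the values given here, the only step that bears on it is the piperidin-1-yl to isobutoxy swap, which moved the number by a modest amount; neither measured compound carries a 4-fluorophenyl there, so there is no direct precedent for an aromatic ring at this position. Given that compound 1, with a ring at this carbon, gave 0.75 nM, a step of similar modest size is expected, leaning toward a lower number, as a 1.6-fold lower number from compound 2 to compound 3 (0.21 log units; within the scatter). Compound 3 is therefore estimated at 1.6 nM, with a range of 0.5 nM to 6 nM.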

Compound 3, half-maximal inhibitory concentration: 1.93 nM
Compound 3: the middle estimate sits 1.2-fold (0.08 log units) below what was measured; measured number inside the range.
By their numbers in this assay, from the lowest: compound 1; then compounds 3 and 2 (each within the scatter of the next).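

In this assay, 4-fluorophenyl in place of isobutoxy on the aromatic carbon next to the ring nitrogen gives a 1.3-fold lower number from compound 2 to compound 3 (0.13 log units; within the scatter) and so does not separate an aromatic ring from an open chain at this position. 4-fluorophenyl in place of piperidin-1-yl gives a 2.6-fold higher number from compound 1 to compound 3 (0.41 log units; beyond the scatter) and so shows that having a ring at this carbon does not by itself match compound 1, whose piperidin-1-yl stands apart beyond the scatter from both other groups. No measurement at hand accounts for these differences.

On these data alone, whether piperidin-1-yl owes its place to being a cyclic amine remains open, and morpholine, pyrrolidine or an open-chain dimethylamino group would bear on that. As far as these compounds go, the part played by the fluorine of 4-fluorophenyl also remains open, and unsubstituted phenyl would address it.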